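A few compounds are considered here, and "the series" means these few. Any claim that something is new, unique, unknown or untested is made for them only; others in the source may bear on it.

Three sulfonamides have so far been measured in a functional assay on MIA PaCa-2 cells (Homo sapiens) for inhibition, read by MTT assay, with a stated time of 72 h; a lower number here means a stronger inhibitor of growth, a higher number a weaker inhibitor of growth. Compound 2 `O=S(=O)(NCCCCNCc1ccc(Br)cc1)c1cc(C(F)(F)F)cc(C(F)(F)F)c1` gives 2100 nM, the lowest of the three numbers. Compound 3 `CC(C)(C)c1ccc(S(=O)(=O)NCCCCCCNCc2ccc(Br)cc2)cc1` gives 2970 nM, which lies within the usual scatter of the number for compound 2, so the two cannot be ranked against each other. Compound 1 `CC(C)(C)c1ccc(CNCCNS(=O)(=O)c2cc(C(F)(F)F)cc(C(F)(F)F)c2)cc1` gives 15000 nM, and its gap to compound 2 lies beyond the scatter. Compound 4 `O=S(=O)(NCCCNCc1ccc(Br)cc1)c1cc(C(F)(F)F)cc(C(F)(F)F)c1` has not yet been measured; it differs from compound 2 in one place: (4-bromobenzyl)amino in place of ((4-bromobenzyl)amino)methyl on a saturated chain carbon, three bonds along the chain from a sulfonamide nitrogen. Within the data shown here, no measured pair shows this exact change. In this assay a modest rise is expected, a 1.9-fold higher number from compound 2 to compound 4 (0.28 log units; within the scatter), probably at the edge of the scatter. Compound 4 is therefore estimated at 4000 nM, within a range from 1500 nM to 12000 nM.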

Compound 4, concentration for 50% growth inhibition: 2300 nM
Beside the measured number, compound 4's estimate is 1.7-fold (0.24 log units) above it, and the stated range covers the measured number.
By their numbers in this assay, from the lowest: compounds 2, 4 and 3 (each within the scatter of the next); then compound 1.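

This is the first pair shown that differs in one place only: in this assay, (4-bromobenzyl)amino in place of ((4-bromobenzyl)amino)methyl gives a 1.1-fold higher number from compound 2 to compound 4 (0.04 log units; within the scatter). At this saturated chain carbon, the two chain lengths therefore cannot be ranked against each other. No measurement shown offers an explanation for this result. From the compounds shown here alone, it remains open whether a still shorter chain would also fall within the scatter of compound 2, and whether an ether oxygen in the chain or a 4-chlorobenzyl group would do the same.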